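A few compounds are considered here, and "the series" means these few. Any claim that something is new, unique, unknown or untested is made for them only; others in the source may bear on it.

Compound 3 `COc1cc(-n2c(-c3ccccc3)csc2=S)cc(OC)c1OC` gives 31.6 ug/mL in a functional assay on T47D cells (Homo sapiens) for cytotoxicity, read by MTT assay, with a stated time of 48 h (on this read-out higher numbers stand for weaker inhibition and lower numbers for stronger inhibition), the highest of the three numbers shown, though its gaps to compound 1 `COc1ccc(C(=O)CSC(=S)Nc2cc(OC)c(OC)c(OC)c2)cc1`, which gives 29.9 ug/mL, and to compound 2 `COc1cc(N2C(=S)SCC2(O)c2ccc(Cl)cc2Cl)cc(OC)c1OC`, which gives 16.9 ug/mL, both lie within the scatter. Compound 4 `COc1cc(-n2c(-c3ccc(F)cc3)csc2=S)cc(OC)c1OC` has not been measured. It differs from compound 3 by fluoro in place of hydrogen on an aromatic carbon, para to a large group. Among the compounds with values here, no measured pair shows this same change, so there is nothing to set the size of the step by. The step is expected to be small, a 1.1-fold lower number from compound 3 to compound 4 (0.05 log units; within the scatter), in no particular direction and not beyond the scatter. Compound 4 is therefore estimated at 28 ug/mL in this assay, with a range from 12 ug/mL to 60 ug/mL.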

Compound 4, half-maximal inhibitory concentration: 38.9 ug/mL
Compound 4: middle estimate off by 1.4-fold (0.14 log units), on the low side; low and high end bracket the measured number.
By their numbers in this assay, from the lowest: compounds 2, 1, 3 and 4 (each within the scatter of the next, the first and the last beyond it).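

In this assay, within the data shown here, this is the first pair to isolate the change, and it gives a 1.2-fold higher number from compound 3 to compound 4 (0.09 log units; within the scatter). Fluoro in place of hydrogen at this position, para to a large group, therefore leaves the number within the scatter, so this single replacement shows no measurable effect on the read-out. Nothing measured here accounts for the size of this step.

The compounds shown leave open whether an amine or a carboxylic acid at the same position would move the number beyond the scatter. They also leave open whether fluoro would behave the same way on a different core.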